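Swapping the Side Group on a Shared Core

The compounds below may be only part of what the source reports. "The series", "measured", "known", "first", "only" and "open" are said of these compounds alone.

Compounds measured so far:
compound 1 `C=C(Br)C(=O)Nc1cccc(-c2cn3nc(Cc4ccccc4)sc3n2)c1`, 4500 nM
compound 2 `C=C(Br)C(=O)Nc1cccc(-c2cn3nc(-c4cccs4)sc3n2)c1`, 670 nM

In a functional assay on HeLa cells (Homo sapiens) for inhibition, read by cell counting, with a stated time of 4 days (on this read-out higher numbers stand for weaker inhibition and lower numbers for stronger inhibition), compound 2 gives the lowest number of the two, with compound 1 the nearest at a 6.7-fold lower number from compound 1 to compound 2 (0.83 log units; beyond the scatter) going the other way. Compound 3 `C=C(Br)C(=O)Nc1cccc(-c2cn3nc(Cc4ccc(OC)cc4)sc3n2)c1` differs from compound 2 in one place: 4-methoxybenzyl in place of thiophen-2-yl on an aromatic carbon. Within the data shown here, the only step that speaks to this change is the one from compound 1 to compound 2, in which a benzyl gave way to thiophen-2-yl and the number fell by a 6.7-fold lower number from compound 1 to compound 2 (0.83 log units; beyond the scatter). Compound 3 carries a 4-methoxybenzyl, a group of the same kind as the benzyl of compound 1, so the change from compound 2 to compound 3 largely undoes that step. The number for compound 3 is therefore expected to rise, roughly by a 5.2-fold higher number from compound 2 to compound 3 (0.72 log units; beyond the scatter), toward the level of compound 1. In this assay compound 3 is estimated at 3500 nM, within a range from 1000 nM to 12000 nM.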

Compound 3, half-maximal inhibitory concentration: 2300 nM
Estimate against measurement, compound 3: 1.5-fold (0.18 log units) above; measured number inside the range.
By their numbers in this assay, from the lowest: compound 2; then compounds 3 and 1 (each within the scatter of the next).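

In this assay, a methoxy on the benzyl group leaves no difference that can be read (a 2.0-fold lower number from compound 1 to compound 3 (0.29 log units; within the scatter)). The thiophen-2-yl compound stays clearly apart from this second benzyl compound as well (a 3.4-fold higher number from compound 2 to compound 3 (0.54 log units; beyond the scatter)), so at this aromatic carbon, compound 1 and compound 3 sit together, with compound 2 alone at the lower number. Nothing available explains this gap.

Compound 2 differs from the two benzyl compounds in two ways at once: the kind of ring, and the missing carbon link between that ring and the shared core. A phenyl joined directly to the core would help separate these two differences, while an amine at the same carbon would show whether a ring is needed there at all.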